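A few compounds are considered here, and "the series" means these few. Any claim that something is new, unique, unknown or untested is made for them only; others in the source may bear on it.

In a functional assay (aorta) with Rattus norvegicus as the target (a higher number here means that more compound is needed for the effect, a lower number that less compound is needed), compound 1 `C/N=C(/S)C1=CC(C)(C(F)(F)F)Oc2ccc([N+](=O)[O-])cc21` gives 0.302 nM, compound 2 `C/N=C(/S)C1=CC(C(F)(F)F)(C(F)(F)F)Oc2ccc([N+](=O)[O-])cc21` gives 0.631 nM and compound 3 `CNC(=O)C1=CC(CF)(CF)Oc2ccc([N+](=O)[O-])cc21` gives 5.13 nM, which places compound 2 second highest of the three. Compound 4 `CNC(=O)C1=CC(C(F)(F)F)(C(F)(F)F)Oc2ccc([N+](=O)[O-])cc21` departs from compound 2 by one exchange: a group of 4 heavy atoms (2 carbon, 1 nitrogen, 1 oxygen; no ring) in place of a group of 4 heavy atoms (2 carbon, 1 nitrogen, 1 sulfur; no ring), on a double-bonded ring carbon. Going by the values given here, the only measured step, a 2.1-fold higher number from compound 1 to compound 2 (0.32 log units; beyond the scatter), is modest and concerns trifluoromethyl in place of methyl on a saturated ring carbon, so it does not test this exchange. The closest guide is compound 3 at 5.13 nM, which also carries methylcarbamoyl but lacks the two trifluoromethyl groups. A larger step towards a higher number is therefore expected, estimated as a 6.3-fold higher number from compound 2 to compound 4 (0.80 log units; beyond the scatter). For compound 4 the expected value is 4 nM, with an estimated range from 1.3 nM to 12 nM.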

Compound 4, half-maximal effective concentration: 1.48 nM
Estimate against measurement, compound 4: 2.7-fold (0.43 log units) above; the measured number falls inside the stated range.
By their numbers in this assay, from the lowest: compound 1; then compound 2; then compound 4; then compound 3.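

Going by these compounds alone, with the two trifluoromethyl groups held fixed, methylcarbamoyl on the double-bonded ring carbon gives in this assay a 2.3-fold higher number from compound 2 to compound 4 (0.37 log units; beyond the scatter) and this is the first direct reading of a change at this position. The exchange of sulfur for oxygen in the group thus moves the number only modestly, and compound 4 gives 1.48 nM in that same assay. No measurement shown here accounts for the step.

The compounds shown leave open how a nitrile or a carboxylic acid would read at this position. They also leave open whether the step would recur with the methyl and trifluoromethyl pair of compound 1.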